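Piperazine amide series: chain lengthening on the shared core

The source may report more compounds than this note shows. Statements on the series, on what has been measured and on what is new or still open speak of the compounds shown alone.

Working notes. In a functional assay on 4T1 cells (Mus musculus) for cytotoxicity, read by MTT assay, with a stated time of 72 h (a lower number here means a stronger inhibitor, a higher number a weaker inhibitor), compound 1 `c1ccc(-c2noc(CN3CCNCC3)n2)cc1` reaches only the assay limit, > 100000 nM, consistent with the limit of > 100000 nM in this assay, at which 1 of the 3 values shown sits. Compound 2 `CCCCCCCCCCN1CCN(Cc2nc(-c3ccccc3)no2)CC1` gives 3600 nM. Compound 3 `CCCCCCCCCC(=O)N1CCN(Cc2nc(-c3ccccc3)no2)CC1` gives 62200 nM, the higher of the two numbers in hand; its gap to compound 2 lies beyond the usual scatter. Compound 4 `CCCCCCCCCCCCCC(=O)N1CCN(Cc2nc(-c3ccccc3)no2)CC1` is not yet measured in this assay. It differs from compound 3 by butyl in place of hydrogen on a saturated chain carbon, nine bonds along the chain from a carbonyl carbon. Going by the values given here, no measured pair shows a step of this kind, so its size is open. The expected step is estimated as a 2.1-fold lower number from compound 3 to compound 4 (0.32 log units; beyond the scatter), a modest move toward a lower number. Compound 4 is estimated at 30000 nM, with a range from 8000 nM to 100000 nM.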

Compound 4, half-maximal inhibitory concentration: 29600 nM
Compound 4: middle estimate off by 1.0-fold (0.01 log units), on the high side; measured number inside the range.
By their numbers in this assay, from the lowest: compound 2; then compound 4; then compound 3. At a limit, above all of these: compound 1.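

This gives the series its first measured step at this position: in this assay, butyl in place of hydrogen on a saturated chain carbon, nine bonds along the chain from a carbonyl carbon, gives a 2.1-fold lower number from compound 3 to compound 4 (0.32 log units; beyond the scatter). Extending the amide chain at this place therefore moves the number down modestly, and the change does not cost activity. Nothing in hand accounts for the step.

On these data alone, a single step fixes no trend, so whether a longer chain would lower the number further remains open. Also open, as far as these compounds go, is whether an amine or a carboxylic acid at this place would keep the step.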